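The source may hold more compounds than are shown below. What is called first, only, known or untested is meant among the compounds shown, and "the series" means these compounds.

Measured compounds:
- compound 1, `CCNC(=O)N1CCN(C(=S)SCc2cn(Cc3ccc(F)cc3)nn2)CC1`: 3660 nM
- compound 2, `CCN(C)C(=O)N1CCN(C(=S)SCc2cn(Cc3ccc(F)cc3)nn2)CC1`: 2150 nM

Both numbers come from a functional assay on MCF7 cells (Homo sapiens) for cytotoxicity, read by MTT assay, with a stated time of 72 h; a lower number here means a stronger inhibitor, a higher number a weaker inhibitor. Compound 1 and compound 2 share one core and differ only at an amide-type nitrogen, where compound 2 carries a methyl in place of the hydrogen of compound 1; this gives a 1.7-fold lower number from compound 1 to compound 2 (0.23 log units; within the scatter), so the two values lie within the scatter of each other and neither can be called the stronger.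

Compound 3, `CCNC(=O)N1CCN(C(=S)SCc2cn(Cc3ccc(OC)cc3)nn2)CC1`, has not been measured. It differs from compound 1 at the other end of the molecule: methoxy in place of fluoro on an aromatic carbon. For the measured compounds named here, the only measured step, from compound 1 to compound 2, alters the amide-type nitrogen and leaves the aromatic ring untouched, so it offers no direct guide to an exchange on that ring. Going by the values given here, with no comparable step available, the expectation for compound 3 is a step of a 1.1-fold lower number from compound 1 to compound 3 (0.06 log units; within the scatter) in this assay, that is, no change beyond the scatter. Compound 3 is therefore estimated at 3200 nM, within a range from 1200 nM to 8500 nM.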

Compound 3, half-maximal inhibitory concentration: 97600 nM
Compound 3: middle estimate off by 31-fold (1.48 log units), on the low side, outside the stated range (above it).
By their numbers in this assay, from the lowest: compounds 2 and 1 (each within the scatter of the next); then compound 3.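

In this assay, the exchange of fluoro for methoxy on the aromatic carbon para to a large group gives a 27-fold higher number from compound 1 to compound 3 (1.43 log units; beyond the scatter), so this position on the 4-fluorobenzyl group is far from indifferent to what it carries. For the compounds shown here, the only earlier step, a 1.7-fold lower number from compound 1 to compound 2 (0.23 log units; within the scatter), stayed within the scatter and said nothing about this ring; here, a swap of one small group for another, with just one more heavy atom, turns compound 3 into a much weaker inhibitor than compound 1. Nothing measured in this set explains the loss.

Going by these compounds alone, with only two groups compared at this carbon, it remains open whether methoxy is what harms the number or fluoro is what favours it, and a bare hydrogen, a chloro, a hydroxyl or an ethoxy group there would help to tell these apart. Going by these compounds, it is also open whether the same exchange would cost as much on the core of compound 2, which carries the extra methyl on the amide-type nitrogen.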